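Pyridin-2-yl Replaces Chlorophenyl on a Limit-Bound Core

The compounds below may be only part of what the source reports. "The series", "measured", "known", "first", "only" and "open" are said of these compounds alone.

Compound 1 `Cc1ccc(-c2ccc(-c3nc4ccc(S(C)(=O)=O)cc4[nH]3)cc2)cc1` in an assay on isolated protein for inhibition of acyl-CoA desaturase 1 (Rattus norvegicus); a higher number here means a weaker inhibitor, a lower number a stronger inhibitor: > 20000 nM
Compound 2 `CS(=O)(=O)c1ccc2nc(-c3ccc(-c4ccc(Cl)cc4)cc3)[nH]c2c1` in this assay : > 20000 nM

The value of compound 1 is a limit of this assay, not a number. The value of compound 2 is likewise a limit. The step from compound 1 to compound 2, a step that the two limits leave unreadable from compound 1 to compound 2, cannot be read, since both ends sit on (the limit of > 20000 nM in this assay, at which 2 of the 2 values shown sit). Compound 2 therefore stands at the limit in this assay, with no finer placement available.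

Compound 3 `CS(=O)(=O)c1ccc2nc(-c3ccc(-c4ccccn4)cc3)[nH]c2c1` differs from compound 2 by pyridin-2-yl in place of 4-chlorophenyl on an aromatic carbon. No measured step bears on this change; the only step shown, from compound 1 to compound 2, is unreadable, so nothing in the data points either way. Compound 3 is thus expected to stay near the limit, with an estimate of 20000 nM and a range from 5000 nM to 80000 nM. The expected step from compound 2 to compound 3 is a number no higher from compound 2 to compound 3 (the limit leaves the size open), not beyond the scatter.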

Compound 3, half-maximal inhibitory concentration: 1710 nM
The estimate for compound 3 lay 12-fold (1.07 log units) above the measured number; the measured number lies below the stated range.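

Of the three compounds, only compound 3 gives a number rather than a limit in this assay, which shows that the group on this aromatic carbon, para to a large group, can move the read-out. Pyridin-2-yl in place of 4-chlorophenyl gives an at least 11-fold lower number from compound 2 to compound 3 (1.06 log units; beyond the scatter), and in place of 4-methylphenyl it gives an at least 11-fold lower number from compound 1 to compound 3 (1.06 log units; beyond the scatter). Compound 1 and compound 2 both remain limits, so the step between them cannot be read and the two steps to compound 3 are bounded by a limit: the limit of > 20000 nM in this assay, at which 2 of the 3 values shown sit.

The compounds shown leave open whether the gain belongs to the ring nitrogen or to the loss of the chlorine or methyl group. They also leave open how an unsubstituted phenyl or a pyridin-3-yl ring would read at this position.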